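The source may hold more compounds than are shown below. What is called first, only, known or untested is meant among the compounds shown, and "the series" means these compounds.

Compound 1 `CC(C)CCn1c(Cn2c(=O)n(C(C)C)c3ccccc32)nc2cc(CN)ccc21`: 3920 nM
Compound 2 `CC(C)CCn1c(Cn2c(=O)n(C(C)C)c3ccccc32)nc2cc(CN(C)C)ccc21`: 5650 nM
Compound 3 `CC(C)CCn1c(Cn2c(=O)n(C(C)C)c3ccccc32)nc2cc(-c3nn[nH]n3)ccc21`: 2000 nM

These values come from an ADME assay on HEp-2 cells (Homo sapiens) for cytotoxicity; on this read-out lower numbers stand for higher toxicity in this test and higher numbers for lower toxicity in this test. Within the data shown here, compound 3 has the lowest number of the three, but the gap to only one neighbour is beyond the scatter: there is a 2.8-fold lower number from compound 2 to compound 3 (0.45 log units; beyond the scatter), against a 2.0-fold lower number from compound 1 to compound 3 (0.29 log units; within the scatter). Next comes compound 4 `CC(C)CCn1c(Cn2c(=O)n(C(C)C)c3ccccc32)nc2cc(N)ccc21`, with amino in place of 2H-tetrazol-5-yl on an aromatic carbon. Among the measured compounds shown here, no measured step makes this exact swap. The two steps above, which bring in 2H-tetrazol-5-yl, both go downward, and a 1.4-fold higher number from compound 1 to compound 2 (0.16 log units; within the scatter) shows little change between the two amine-bearing compounds. Removing that group should therefore give a small rise. Expected is a 1.8-fold higher number from compound 3 to compound 4 (0.24 log units; within the scatter), which may stay within the scatter. For compound 4 the estimated value is 3500 nM, with a range from 1500 nM to 8000 nM.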

Compound 4, half-maximal cytotoxic concentration: 32200 nM
Compound 4: middle estimate off by 9.2-fold (0.96 log units), on the low side, and the stated range ends below it.
By their numbers in this assay, from the lowest: compounds 3, 1 and 2 (each within the scatter of the next, the first and the last beyond it); then compound 4.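

Amino bound directly to this aromatic carbon sets compound 4 apart from all three earlier compounds (a 16-fold higher number from compound 3 to compound 4 (1.21 log units; beyond the scatter); a 5.7-fold higher number from compound 2 to compound 4 (0.76 log units; beyond the scatter); an 8.2-fold higher number from compound 1 to compound 4 (0.91 log units; beyond the scatter)), and each higher number means lower toxicity in this test. Compound 1 and compound 2 also carry an amine, but on a saturated chain carbon, so an amine in this region does not by itself bring the high number. Nothing available explains the jump. Going by these compounds, whether it is specific to amino remains open: hydroxyl or methylamino on this aromatic carbon could test that.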